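Replacing the naphthyl group on the shared core

A few compounds are considered here, and "the series" means these few. Any claim that something is new, unique, unknown or untested is made for them only; others in the source may bear on it.

compound 1 `O=C(O)CC/C=C\CC1COC(c2ccc([N+](=O)[O-])cc2)OC1c1cccnc1`: 39 nM
compound 2 `O=C(O)CC/C=C\CC1COC(c2ccc3ccccc3c2)OC1c1cccnc1`: 50 nM

In an assay for inhibition of Thromboxane-A synthase (Homo sapiens), using microsomes (on this read-out higher numbers stand for weaker inhibition and lower numbers for stronger inhibition), compound 1 gives 39 nM, and in the same read-out compound 2 gives 50 nM. Compound 2 carries the highest number of the pair; its nearest neighbour is compound 1. For the measured compounds named here, the single measured step, a 1.3-fold higher number from compound 1 to compound 2 (0.11 log units; within the scatter), lies within the scatter, so the two values show no difference that can be read as change.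

Compound 3 `CC(C)(Oc1ccccc1)C1OCC(C/C=C\CCC(=O)O)C(c2cccnc2)O1` is the next member. Relative to compound 2 it carries a group of 10 heavy atoms (9 carbon, 1 oxygen; one six-membered aromatic ring of carbon only) in place of a group of 10 heavy atoms (10 carbon; 2 six-membered aromatic rings of carbon only), on a saturated ring carbon. Going by the values given here, this is the same place on the shared core that was altered in the only step known, and that step, a 1.3-fold higher number from compound 1 to compound 2 (0.11 log units; within the scatter), stayed within the scatter. Nothing else in the data bears on the change. No step beyond the scatter is therefore expected in this assay, although the entering group, with its oxygen and single aromatic ring, is of a different kind from either group already measured. Compound 3 is estimated at 60 nM, range 20 nM to 180 nM, meaning an expected step of a 1.2-fold higher number from compound 2 to compound 3 (0.08 log units; within the scatter).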

Compound 3, half-maximal inhibitory concentration: 52 nM
Beside the measured number, compound 3's estimate is 1.2-fold (0.06 log units) above it; measured number inside the range.
By their numbers in this assay, from the lowest: compounds 1, 2 and 3 (each within the scatter of the next).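

In this assay the change from naphthalen-2-yl to the group with one six-membered aromatic ring and one oxygen gives a 1.0-fold higher number from compound 2 to compound 3 (0.02 log units; within the scatter) and the change from 4-nitrophenyl to that same group gives a 1.3-fold higher number from compound 1 to compound 3 (0.12 log units; within the scatter) at this place. For the compounds shown here, the saturated ring carbon between two ring oxygen atoms has now carried three groups of different atom make-up with no step beyond the scatter, so the reading from the single earlier step extends to a group of a different kind. Nothing available accounts for this outcome.

As far as these compounds go, whether a group without an aromatic ring, such as methyl or cyclohexyl, or a chain ending in an amine would stay at the same level at this place remains open. From the compounds shown here alone, the pyridin-3-yl and 5-carboxypent-2-en-1-yl groups are the same in all three compounds, so what changes there would do also remains open.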